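The compounds below may be only part of what the source reports. "The series", "measured", "known", "first", "only" and "open" are said of these compounds alone.

Values so far in a functional assay on RT-112 cells (Homo sapiens) for antiproliferative activity, read by MTT assay, with a stated time of 72 h; a lower number here means a stronger inhibitor of growth, a higher number a weaker inhibitor of growth:
Compound 1 `COc1cc(Nc2ncnc3c(NC(=O)Nc4cc(Cl)cc(Cl)c4)cccc23)cc(OC)c1` gives 30.2 nM
Compound 2 `COc1cc(Nc2ncnc3c(NC(=O)Nc4cc(C)cc(C)c4)cccc23)cc(OC)c1` gives 10100 nM

Among the compounds with values here, compound 2 holds the higher of the two numbers, at 10100 nM in this assay, and its only neighbour is compound 1. Within the data shown here, the single measured step, a 330-fold higher number from compound 1 to compound 2 (2.52 log units; beyond the scatter), swaps 3,5-dichlorophenyl for 3,5-dimethylphenyl and lies well beyond the scatter.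

Compound 3 `COc1cc(Nc2ncnc3c(NC(=O)Nc4ccc(C(F)(F)F)cc4Cl)cccc23)cc(OC)c1` keeps the shared core and differs from compound 2 at one place: 2-chloro-4-(trifluoromethyl)phenyl in place of 3,5-dimethylphenyl on an amide-type nitrogen. The incoming group has no methyl and carries chlorine, as the group of compound 1 does. Among the measured compounds shown here, it is not 3,5-dichlorophenyl, however, and no measured compound carries trifluoromethyl. For the measured compounds named here, the only guide is therefore a 330-fold higher number from compound 1 to compound 2 (2.52 log units; beyond the scatter), read in reverse and with caution. A large move to a lower number is expected, probably not the whole way back to compound 1.

The estimated change is a 67-fold lower number from compound 2 to compound 3 (1.83 log units; beyond the scatter), with wide uncertainty. For compound 3 the expected value is 150 nM, with an estimated range of 25 nM to 1500 nM in this assay.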

Compound 3, concentration for 50% growth inhibition: 1080 nM
Compound 3: the middle estimate sits 7.2-fold (0.86 log units) below what was measured; the range from low to high includes it.
By their numbers in this assay, from the lowest: compound 1; then compound 3; then compound 2.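

In (this assay), the step from the 3,5-dimethylphenyl group to the 2-chloro-4-(trifluoromethyl)phenyl group on the amide-type nitrogen (a 9.4-fold lower number from compound 2 to compound 3 (0.97 log units; beyond the scatter)) shows that a group without methyl and with chlorine can give a lower number than compound 2 while recovering only part of the gap to compound 1. The matching step from the 3,5-dichlorophenyl group (a 36-fold higher number from compound 1 to compound 3 (1.55 log units; beyond the scatter)) shows that the presence of chlorine alone does not reproduce the value of compound 1, and that this position separates three substituted phenyl groups by amounts beyond the scatter, with compound 1 giving the lowest number. No accompanying data explain the differences among these three groups.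

The 2-chloro-4-(trifluoromethyl)phenyl group differs from the 3,5-dichlorophenyl group in both its substituents and their placement, so the contribution of each change cannot be separated from these compounds. On these data alone, it remains open how a plain phenyl, a fluorine-bearing phenyl or a phenyl carrying an amine or a carboxylic acid would read at this position, and whether the same order holds on a different core.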